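Chloro for Trifluoromethyl on the Urea Aryl Ring

A few compounds are considered here, and "the series" means these few. Any claim that something is new, unique, unknown or untested is made for them only; others in the source may bear on it.

Three compounds have been measured in a functional assay on HCT-15 cells (Homo sapiens) for inhibition, read by sulforhodamine B assay, with a stated time of 48 h, tested at 10 uM; a higher number here means a weaker effect of the compound at the concentration tested, a lower number a stronger effect:

Compound 1 `O=C(Nc1cccc(-n2cc(-c3ccncc3)c(-c3cc(O)cc(Cl)c3)n2)c1)Nc1ccc(Cl)c(C(F)(F)F)c1` gives 5.79%.
Compound 2 `O=C(Nc1cccc(-n2cc(-c3ccncc3)c(-c3cc(O)cc(Cl)c3)n2)c1)Nc1ccc(Cl)c(Cl)c1` gives -25.3%.
Compound 3 `COc1cc(Cl)cc(-c2nn(-c3cccc(NC(=O)Nc4ccc(Cl)c(C(F)(F)F)c4)c3)cc2-c2ccncc2)c1` gives 7.28%.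

Compound 2 differs from compound 1 by chloro in place of trifluoromethyl on an aromatic carbon. In this assay this produced a number 31.1 percentage points lower from compound 1 to compound 2 (beyond the scatter). Compound 3 differs from compound 1 by methyl in place of hydrogen on an oxygen on an aromatic ring, a difference between the two cores that in this assay gave only a number 1.5 percentage points higher from compound 1 to compound 3 (within the scatter); compound 1 and compound 3 therefore stand together, and compound 2 lies beyond both.

Compound 4 `COc1cc(Cl)cc(-c2nn(-c3cccc(NC(=O)Nc4ccc(Cl)c(Cl)c4)c3)cc2-c2ccncc2)c1` has not yet been measured. It differs from compound 3 by chloro in place of trifluoromethyl on an aromatic carbon. The place of this change reads the same, word for word, as the place of the change from compound 1 to compound 2, so it is the same change carried onto the methoxy-bearing core. Compound 4 is expected to move by a number 29.3 percentage points lower from compound 3 to compound 4 (beyond the scatter) in this assay. This expectation rests on compound 1 and compound 2, where the same change gave a number 31.1 percentage points lower from compound 1 to compound 2 (beyond the scatter), and on compound 3 sitting where compound 1 sits. Compound 4 is thus estimated at -22%, between -45% and 5%.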

Compound 4, a percentage reported as activity, at one concentration (the size of the read-out at that concentration, not a potency): 13.9%
The estimate for compound 4 lay 35.9 percentage points below the measured number; measured number above the stated range.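

Chloro in place of trifluoromethyl does not carry from one core to the other in this assay; on the methoxy-bearing core it gives only a number 6.6 percentage points higher from compound 3 to compound 4 (within the scatter), and the two steps differ: the same change on two cores in this assay, a number 31.1 percentage points lower (beyond the scatter) from compound 1 to compound 2 and a number 6.6 percentage points higher (within the scatter) from compound 3 to compound 4, 37.7 percentage points apart, beyond the scatter of two such steps
Read the other way, methyl in place of hydrogen on the oxygen gives a number 39.2 percentage points higher from compound 2 to compound 4 (beyond the scatter), so this change too depends on its partner, here the 3,4-dichlorophenyl group rather than the 4-chloro-3-(trifluoromethyl)phenyl group: the same change on two cores in this assay, a number 1.5 percentage points higher (within the scatter) from compound 1 to compound 3 and a number 39.2 percentage points higher (beyond the scatter) from compound 2 to compound 4, 37.7 percentage points apart, beyond the scatter of two such steps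
The four compounds thus show that neither step can be moved unchanged between these two cores, but they do not show why, and each step beyond the scatter involves compound 2, so the whole dependence rests on this one compound.

On these data alone, it remains open whether a repeat measurement would hold the value of compound 2 at -25.3%. As far as these compounds go, it also remains open how an ethoxy group on the core, or a fluoro or nitrile group in place of the trifluoromethyl, would behave.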